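The source may hold more compounds than are shown below. What is called first, only, known or untested is meant among the compounds shown, and "the series" means these compounds.

Measured so far:
compound 1 `Cc1noc(-c2ccc(O[C@H]3CCC[C@H](C(=O)O)C3)cc2)c1COC(=O)N(C)CCC(C)C`: 0.003
compound 2 `CN(CC1CCC1)C(=O)OCc1c(-c2ccc(O[C@H]3CCC[C@H](C(=O)O)C3)c(C(F)F)n2)nnn1C`: 0.001

In an ADME assay on the whole organism (plasma, Homo sapiens) for protein binding, read by LC-MS, with a stated time of 24 h (a higher number here means a larger unbound share of the compound, a lower number a smaller unbound share), compound 1 gives 0.003, the higher of the two numbers, while compound 2 gives 0.001. The gap between these two values lies beyond the usual scatter, but both unbound fractions are small.

The next compound is compound 3 `Cc1noc(-c2ccc(O[C@H]3CCC[C@H](C(=O)O)C3)cc2)c1CNC(=O)OCc1ccccc1`, which keeps the core of compound 1 and changes one group: a group of 11 heavy atoms (8 carbon, 1 nitrogen, 2 oxygen; one six-membered aromatic ring of carbon only) in place of a group of 10 heavy atoms (7 carbon, 1 nitrogen, 2 oxygen; no ring), on a saturated chain carbon bound to an aromatic carbon. The new (benzyloxycarbonyl)amino group sits on a saturated chain carbon bound to an aromatic carbon.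

Within the data shown here, no step between measured compounds that differ in one place is available, so the size of this change has not been observed directly. In this assay no step beyond the scatter is expected, and this expectation rests mainly on compound 1 at 0.003. The expected step is no change at the digits printed from compound 1 to compound 3 (within the scatter).

Compound 3 is estimated at 0.003, with an expected range from 0.0012 to 0.007.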

Compound 3, unbound fraction: 0.005
Compound 3: middle estimate off by 1.7-fold (0.22 log units), on the low side; measured number inside the range.
By their numbers in this assay, from the lowest: compound 2; then compounds 1 and 3 (each within the scatter of the next).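

In this assay, among these compounds, the exchange on the saturated chain carbon bound to an aromatic carbon gives the first directly observed step at this position: a 1.7-fold higher number from compound 1 to compound 3 (0.22 log units; within the scatter). The (benzyloxycarbonyl)amino group, with its six-membered aromatic ring of carbon only and its hydrogen-bond donor, therefore cannot be told apart in this read-out from the group of 10 heavy atoms without a ring that it replaces, and this single pair gives no sign that the position responds to this exchange. No separate measurement on hand bears on the origin of this result.

The ring and the hydrogen-bond donor enter together in compound 3, so this one step cannot assign any share of the read-out to either feature, and a methyl group on the carbamate nitrogen with the benzyl group kept would separate the two. Also open, as far as these compounds go, is whether a more different group at this place, such as a primary amine, a carboxylic acid or a longer alkyl chain, would give a step beyond the scatter on the core of compound 1.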